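Compound 4 against compound 2: exchange of the ether group

This account rests on a few compounds, and the source may have more. Where it says the series, first, only, none or still open, it means among the compounds named here.

Among the measured compounds shown here, compound 2 `COC(=O)c1ccccc1OCc1cn(-c2ccc(S(=O)(=O)N3CCc4ccccc4C3)cc2)nn1` gives 570 nM in a functional assay on A549 cells (Homo sapiens) for cytotoxicity, read by MTT assay, with a stated time of 48 h (on this read-out higher numbers stand for weaker inhibition and lower numbers for stronger inhibition), the lowest of the three numbers known so far. Its nearest neighbour is compound 3 `COc1cc2c(cc1OC)CN(S(=O)(=O)c1ccc(-n3cc(COc4ccc(C=O)cc4)nn3)cc1)CC2`, which gives 31800 nM in this assay, while compound 1 `Cc1ccccc1OCc1cn(-c2ccc(S(=O)(=O)N3CCc4ccccc4C3)cc2)nn1` gives 66300 nM. For the measured compounds named here, the single step between compounds that differ in one place is a 120-fold lower number from compound 1 to compound 2 (2.07 log units; beyond the scatter), a large movement from one substituent alone on the group that is now to be exchanged.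

Compound 4 `O=c1cc(OCc2cn(-c3ccc(S(=O)(=O)N4CCc5ccccc5C4)cc3)nn2)c2ccccc2o1` differs from compound 2 by a group of 11 heavy atoms (9 carbon, 2 oxygen; one six-membered aromatic ring of carbon only, one six-membered aromatic ring with 1 hetero atom) in place of a group of 10 heavy atoms (8 carbon, 2 oxygen; one six-membered aromatic ring of carbon only), on an oxygen on a saturated carbon. Going by the values given here, no measured step covers this kind of change. The step from compound 1 to compound 2 concerns only a substituent on the ring that leaves and cannot say what the exchange of the whole group will do, so it sets no direction here. Since compound 2 holds the lowest number and both other compounds stand far higher, the working expectation is a moderate rise in the read-out rather than a further drop, with wide uncertainty. The step expected is a 5.3-fold higher number from compound 2 to compound 4 (0.72 log units; beyond the scatter). Compound 4 is therefore estimated at 3000 nM, with a range from 500 nM to 20000 nM.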

Compound 4, half-maximal inhibitory concentration: 25300 nM
Estimate against measurement, compound 4: 8.4-fold (0.93 log units) below, and the stated range ends below it.
By their numbers in this assay, from the lowest: compound 2; then compounds 4 and 3 (each within the scatter of the next); then compound 1.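

In this assay, exchanging the 2-(methoxycarbonyl)phenyl group on the oxygen on a saturated carbon for the two-ring group of compound 4 gives a 44-fold higher number from compound 2 to compound 4 (1.65 log units; beyond the scatter) and so loses most of what set compound 2 apart, even though the counts of hydrogen-bond donors, hydrogen-bond acceptors and double bonds outside aromatic rings stay the same. Set against the single-ring group of compound 1, the same two-ring group gives only a 2.6-fold lower number from compound 1 to compound 4 (0.42 log units; beyond the scatter) as a modest step, so this position responds strongly to the whole group that sits there, and the low number of compound 2 belongs to its particular group rather than to any group with these counts. Nothing available accounts for the size of either step.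

On these data alone, whether the low number depends on the methoxycarbonyl group itself stays open, since a carboxylic acid or a primary amide in its place would test this directly. Also open, as far as these compounds go, is how a plain phenyl group or a longer chain on the same oxygen would read in this assay, which would show how far the series depends on the entering ring.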